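From Fluoro to Nitro on the Shared Core

A few compounds are considered here, and "the series" means these few. Any claim that something is new, unique, unknown or untested is made for them only; others in the source may bear on it.

compound 1 `COc1cc(-c2ncnn2-c2cccc(F)c2)cc(OC)c1OC` — in a functional assay on HeLa cells (Homo sapiens) for antiproliferative activity, read by MTT assay, with a stated time of 72 h (a higher number here means a weaker inhibitor, a lower number a stronger inhibitor), compound 1 gives > 10000 nM, a limit of the assay.
compound 2 `COc1cc(-c2ncnn2-c2ccc(Cl)cc2)cc(OC)c1OC` — in this assay compound 2 gives > 10000 nM, again a limit of the assay.

Compound 1 therefore stands only at a limit in this assay; no number is known for it. Among the compounds with values here, the one step measured so far, a step that the two limits leave unreadable from compound 1 to compound 2 (4-chlorophenyl in place of 3-fluorophenyl on an aromatic nitrogen), cannot be read in size, because of the limit of > 10000 nM in this assay, at which 2 of the 2 values shown sit.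

Compound 3 `COc1cc(-c2ncnn2-c2cccc([N+](=O)[O-])c2)cc(OC)c1OC` differs from compound 1 by nitro in place of fluoro on an aromatic carbon. This change sits on the same phenyl ring that was varied between compound 1 and compound 2, but it is a different group at a different place on that ring, so the measured step bears on it only by showing that two variations of this ring left the compound at the limit. No direction or size of step in this assay can be read from the data; the only expectation available is that compound 3 is likely to remain at or near the limit as well.

Compound 3 is thus expected to give about 15000 nM in this assay, within 4000 nM to 60000 nM, which is estimated as a step that the limit leaves unreadable from compound 1 to compound 3 from compound 1.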

Compound 3, half-maximal inhibitory concentration: > 10000 nM
Compound 3 gave a limit, no number; the forecaster's own chance of this, stated with the estimate: 75%; the middle value does not contradict the limit.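

Within the data shown here, compound 3, like compound 1 and compound 2, stands only at a limit in this assay, so the change from compound 1 to compound 3 gives no step that can be read in size: the limit of > 10000 nM in this assay, at which 3 of the 3 values shown sit. The compounds shown leave open what number any of the three would reach, and whether any change on this phenyl ring moves it.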